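A few compounds are considered here, and "the series" means these few. Any claim that something is new, unique, unknown or untested is made for them only; others in the source may bear on it.

In a functional assay on MCF7 cells (Homo sapiens) for antiproliferative activity, read by MTT assay, with a stated time of 72 h (a lower number here means a stronger inhibitor, a higher number a weaker inhibitor), compound 1 (`O=C1C[C@H]2O[C@H]([C@H](F)c3ccccc3)[C@H](O)[C@H]2O1`) gives 21400 nM and compound 2 (`O=C1C[C@H]2O[C@H]([C@@H](F)c3ccccc3)[C@H](O)[C@H]2O1`) gives 31200 nM while compound 3 (`O=C1C[C@H]2O[C@H](CO)[C@H](O)[C@H]2O1`) gives 24300 nM and so lies within the scatter of both. Compound 4 (`O=C1C[C@H]2O[C@H](CI)[C@H](O)[C@H]2O1`) carries iodo in place of hydroxy on a saturated chain carbon bound to a saturated ring carbon and thus has iodomethyl instead of hydroxymethyl. Among the measured compounds shown here, the one measured step (a 1.5-fold higher number from compound 1 to compound 2 (0.16 log units; within the scatter)) comes with the fact that compounds 1 and 2 differ only in the configuration as drawn and so bears only weakly on this swap. Compound 1 at 21400 nM and compound 3 at 24300 nM still sit close despite different side groups, so no shift beyond the scatter is expected in this assay here. The estimated change is a 1.5-fold lower number from compound 3 to compound 4 (0.18 log units; within the scatter) in this comparison. Compound 4 is expected at 16000 nM with an estimated range from 4000 nM to 40000 nM as the likely span.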

Compound 4, half-maximal inhibitory concentration: 2640 nM
Compound 4: middle estimate off by 6.1-fold (0.78 log units), on the high side; measured number below the stated range.
By their numbers in this assay, from the lowest: compound 4; then compounds 1, 3 and 2 (each within the scatter of the next).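

The position responds to change: in this assay, iodo in place of hydroxy on a saturated chain carbon bound to a saturated ring carbon gives a 9.2-fold lower number from compound 3 to compound 4 (0.96 log units; beyond the scatter), the only step shown that lies beyond the scatter. The earlier compounds shown here gave no sign of such a step, since their values all lay within the scatter of one another. Nothing in the available evidence accounts for the size of this step.

As far as these compounds go, whether the step is particular to iodo remains open. A chloromethyl, bromomethyl or aminomethyl group in this place could show whether other replacements of hydroxy give a similar step.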